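The source may hold more compounds than are shown below. What is called first, only, known or untested is meant among the compounds shown, and "the series" means these compounds.

In a functional assay on HepG2 cells (Homo sapiens) for cytotoxicity, read by MTT assay, with a stated time of 24 h (on this read-out lower numbers stand for stronger inhibition and higher numbers for weaker inhibition), compound 1 (`COc1cc(/C=C2\CN(S(=O)(=O)c3ccc(F)cc3)C/C(=C\c3cc(OC)c(OC)c(OC)c3)C2=O)cc(OC)c1OC`) stands at 4200 nM and lies within the scatter of the other two numbers, with compound 2 (`COc1cc(/C=C2\CN(S(=O)(=O)c3ccc(F)cc3)C/C(=C\c3cc(OC)cc(OC)c3)C2=O)cc(OC)c1`) at 8100 nM and compound 3 (`COc1cc(/C=C2\CN(S(=O)(=O)c3ccc(NC(C)=O)cc3)C/C(=C\c3cc(OC)c(OC)c(OC)c3)C2=O)cc(OC)c1OC`) at 3890 nM in this series. Compound 4 (`COc1cc(/C=C2\CN(S(=O)(=O)c3ccc(F)cc3)C/C(=C\c3ccc(C#N)cc3)C2=O)cc(OC)c1OC`) carries 4-cyanophenyl in place of 3,4,5-trimethoxyphenyl on a double-bonded chain carbon bound to a double-bonded ring carbon. Going by the values given here, the one measured single-place step (a 1.1-fold lower number from compound 1 to compound 3 (0.03 log units; within the scatter)) is acetamido in place of fluoro on an aromatic carbon, so it bears only indirectly, and no measured step tests this place alone. Among the compounds with values here, compound 2 differs from compound 1 in more than one place and gives no clean step. No step beyond the scatter is therefore expected in this assay, in either direction. The expected step is small (a 1.1-fold lower number from compound 1 to compound 4 (0.02 log units; within the scatter)). For compound 4 the estimated value is 4000 nM (expected range 1500 nM to 11000 nM).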

Compound 4, half-maximal inhibitory concentration: 4950 nM
For compound 4 the middle estimate is 1.2-fold (0.09 log units) below the measured one; low and high end bracket the measured number.
By their numbers in this assay, from the lowest: compounds 3, 1, 4 and 2 (each within the scatter of the next, the first and the last beyond it).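

In this assay, the exchange at this position, on a double-bonded chain carbon bound to a double-bonded ring carbon, gives a 1.2-fold higher number from compound 1 to compound 4 (0.07 log units; within the scatter). Going by these compounds alone, this is the first single-place reading here: 3,4,5-trimethoxyphenyl on this arm can give way to 4-cyanophenyl without a step beyond the scatter, while the second 3,4,5-trimethoxyphenyl stays in place. No available evidence bears on why this step is so small.

Open, as far as these compounds go, is whether a carboxylic acid or a dimethylamino group on this phenyl ring would also stay within the scatter. Also open, from the compounds shown here alone, is whether replacing both 3,4,5-trimethoxyphenyl groups with 4-cyanophenyl would do so.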